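Ortho trifluoromethyl on the benzoyl of a triazene amide

This account rests on a few compounds, and the source may have more. Where it says the series, first, only, none or still open, it means among the compounds named here.

Of the compounds shown here, three of a shared core have been measured in a functional assay on HeLa cells (Homo sapiens) for cytotoxicity, read by MTT assay, with a stated time of 72 h; on this read-out lower numbers stand for stronger inhibition and higher numbers for weaker inhibition. Compound 1 `CC(=O)OCC(=O)N(/N=N/c1ccc([N+](=O)[O-])cc1Br)c1ccc([N+](=O)[O-])cc1Br` gives 490 nM, compound 2 `O=[N+]([O-])c1ccc(/N=N/Nc2ccc([N+](=O)[O-])cc2Cl)c(Cl)c1` gives 3010 nM, and compound 3 `O=C(c1ccccc1)N(/N=N/c1ccc([N+](=O)[O-])cc1Cl)c1ccc([N+](=O)[O-])cc1Cl` gives 590 nM. Going by the values given here, compound 3 stands second highest of the three numbers; its nearest neighbour is compound 1, whose number is within the scatter of it, and its furthest is compound 2, separated from it by the one measured step, a 5.1-fold lower number from compound 2 to compound 3 (0.71 log units; beyond the scatter), which is the only change among the measured compounds that touches the nitrogen bearing the acyl group.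

Compound 4 `O=C(c1ccccc1C(F)(F)F)N(/N=N/c1ccc([N+](=O)[O-])cc1Cl)c1ccc([N+](=O)[O-])cc1Cl` differs from compound 3 by trifluoromethyl in place of hydrogen on an aromatic carbon. Among the compounds with values here, no measured step alters the benzoyl ring itself, so nothing in the data speaks for or against a change at this position; the one measured step concerns the presence of the benzoyl as a whole, not its substitution. The expected step from compound 3 to compound 4 in this assay is therefore a 1.1-fold lower number from compound 3 to compound 4 (0.03 log units; within the scatter), a difference judged to lie within the scatter.

On that basis the estimate for compound 4 in this assay is 550 nM, with a range from 200 nM to 1600 nM.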

Compound 4, half-maximal inhibitory concentration: 10600 nM
Compound 4: middle estimate off by 19-fold (1.28 log units), on the low side; the whole stated range lies below it.
By their numbers in this assay, from the lowest: compounds 1 and 3 (each within the scatter of the next); then compound 2; then compound 4.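

In this assay the step of an 18-fold higher number from compound 3 to compound 4 (1.25 log units; beyond the scatter) shows that the benzoyl ring does not tolerate every substitution: a single trifluoromethyl on an aromatic carbon, ortho to a large group, is enough to move the number far beyond the scatter. The earlier compounds shown here showed only that the benzoyl as a whole goes with a lower number, in the step of a 5.1-fold lower number from compound 2 to compound 3 (0.71 log units; beyond the scatter) and this new step runs the other way and is larger, leaving compound 4 at 10600 nM above even compound 2 at 3010 nM in the printed values. Nothing at hand accounts for this rise, so its cause remains unknown.

The compounds shown leave open whether the rise belongs to trifluoromethyl itself or to any substituent at this place on the ring, a question that a fluorine atom, a methyl or a methoxy group there would help to settle. They also leave open whether trifluoromethyl elsewhere on the benzoyl ring, or a nitrile or a carboxylic acid in its stead, would give a step of similar size.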